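Swapping a hydroxy for an acetamido on an indolyl thiourea

This account rests on a few compounds, and the source may have more. Where it says the series, first, only, none or still open, it means among the compounds named here.

Compound 1 `Oc1ccc(NC(=S)Nc2ccc3[nH]ccc3c2)cc1` is the starting point. Going by the values given here, in an assay on cells for inhibition of Amine oxidase [flavin-containing] B (Homo sapiens), read by spectrophotometry (a lower number here means a stronger inhibitor, a higher number a weaker inhibitor), compound 1 gives 17000 nM, the lowest of the two numbers measured so far. Its closest neighbour, compound 2 `COc1ccc(NC(=S)Nc2ccc3[nH]ccc3c2)cc1`, gives 37000 nM in this assay. Among the compounds with values here, the one measured step, a 2.2-fold higher number from compound 1 to compound 2 (0.34 log units; beyond the scatter), comes from placing a methyl in place of hydrogen on an oxygen on an aromatic ring, and it weakened inhibition by a modest amount.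

Compound 3 `CC(=O)Nc1ccc(NC(=S)Nc2ccc3[nH]ccc3c2)cc1` has not yet been measured. It differs from compound 1 as follows: acetamido in place of hydroxy on an aromatic carbon. The acetamido keeps one hydrogen-bond donor and one hydrogen-bond acceptor, as the hydroxy did, but it is larger. Within the data shown here, the only step that bears on the position is the one from compound 1 to compound 2, where a change at this same aromatic carbon raised the number modestly. A rise of similar size, or none beyond the scatter, is therefore expected in this assay. For compound 3 the expected value is 25000 nM, within a range from 8000 nM to 80000 nM. The step expected is a 1.5-fold higher number from compound 1 to compound 3 (0.17 log units; within the scatter).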

Compound 3, half-maximal inhibitory concentration: 37000 nM
Beside the measured number, compound 3's estimate is 1.5-fold (0.17 log units) below it, within the range that was stated.
By their numbers in this assay, from the lowest: compound 1; then compounds 2 and 3 (each within the scatter of the next).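

In this assay, the acetamido, with 4 heavy atoms in place of the single oxygen of the hydroxy, gives a 2.2-fold higher number from compound 1 to compound 3 (0.34 log units; beyond the scatter) and so joins the methoxy in weakening inhibition by a modest amount. It does so even though its counts of hydrogen-bond donors and acceptors match those of the hydroxy, and the comparison of the two replacements gives no change at the digits printed from compound 2 to compound 3 (within the scatter) so these two groups cannot be told apart here, while the hydroxy of compound 1 remains the strongest inhibitor of the three. No measurement shown explains why either replacement raises the number.

The compounds shown leave open whether an amine or a carboxylic acid on this aromatic carbon would match the hydroxy or give a lower number than compound 1 does. They also leave open whether a longer chain in place of the acetamido would raise the number further or leave it where compound 2 and compound 3 stand.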